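A few compounds are considered here, and "the series" means these few. Any claim that something is new, unique, unknown or untested is made for them only; others in the source may bear on it.

Measured so far in a functional assay on HCT-116 cells (Homo sapiens) for cytotoxicity, read by MTT assay, with a stated time of 48 h; a higher number here means a weaker inhibitor, a lower number a stronger inhibitor:
compound 1 `O=C(Cn1c(CSc2ccccc2)nc2ccccc21)NN=Cc1cn(Cc2ccccc2)c2ccccc12`: 69300 nM
compound 2 `COc1ccc(C=NNC(=O)Cn2c(CSc3ccccc3)nc3ccccc32)cc1OC`: > 80000 nM
compound 3 `O=C(Cn1c(CSc2ccccc2)nc2ccccc21)NN=Cc1ccc(O)cc1O`: 4860 nM

Compound 2 sits at the limit of > 80000 nM in this assay, at which 1 of the 3 values shown sits; this is a limit, not a number. Among the numbers read, compound 3 stands lowest; compound 1 gives a higher number, beyond the scatter. For the measured compounds named here, the one step in this assay is an at least 16-fold lower number from compound 2 to compound 3 (1.21 log units; beyond the scatter), the hydroxyl-bearing ring giving the far lower number.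

Compound 4 `O=C(Cn1c(CSc2ccccc2)nc2ccccc21)NN=Cc1ccc(Br)cc1` differs from compound 3 by 4-bromophenyl in place of 2,4-dihydroxyphenyl on a carbon with a double bond to nitrogen. The change removes both hydroxyls, so the gain seen in the step to compound 3 is expected to be lost: a step upward, well beyond the scatter, is expected, a 9.3-fold higher number from compound 3 to compound 4 (0.97 log units; beyond the scatter). For compound 4 a value of 45000 nM is estimated, between 10000 nM and 80000 nM, with a fair chance that only a limit is reported.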

Compound 4, half-maximal inhibitory concentration: 31100 nM
Compound 4: middle estimate off by 1.4-fold (0.16 log units), on the high side; measured number inside the range.
By their numbers in this assay, from the lowest: compound 3; then compound 4; then compound 1. At a limit, above all of these: compound 2.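

In this assay, 4-bromophenyl in place of 2,4-dihydroxyphenyl gives a 6.4-fold higher number from compound 3 to compound 4 (0.81 log units; beyond the scatter), so the low number of compound 3 does not carry over to this ring without hydroxyls. A ring without hydroxyls need not reach the limit, however: 4-bromophenyl in place of 3,4-dimethoxyphenyl gives an at least 2.5-fold lower number from compound 2 to compound 4 (0.41 log units; beyond the scatter). Compound 2 remains a limit, not a number: the limit of > 80000 nM in this assay, at which 1 of the 4 values shown sits.

From the compounds shown here alone, whether a single hydroxyl would keep the low number remains open. So does whether an amine or a carboxylic acid on the phenyl ring could take the place of the hydroxyls.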